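Capping one hydroxy group on a weak compound

The source may hold more compounds than are shown below. What is called first, only, known or untested is meant among the compounds shown, and "the series" means these compounds.

In a functional assay on A-375 cells (Homo sapiens) for antiproliferative activity, read by MTT assay, with a stated time of 96 h (a lower number here means a stronger inhibitor, a higher number a weaker inhibitor), compound 1 (`COc1c(O)cc2cc1C[C@H](C)C[C@H](OC)[C@H](O)[C@@H](C)/C=C(\C)C[C@H](OC(N)=O)[C@@H](OC)CC/C=C(\C)C(=O)N2`) gives 2290 nM as its half-maximal inhibitory concentration. Compound 2 (`COc1ccc([C@H]2c3cccc(c3O)NC(=O)/C(C)=C/CC[C@H](OC)[C@@H](OC(N)=O)/C(C)=C/[C@H](C)[C@@H](O)[C@@H](OC)C[C@@H]2C)cc1`) stands at > 20000 nM in this assay and that reading is a limit of the assay, not a number. Compound 3 (`COc1ccc([C@H]2c3cccc(c3O)NC(=O)/C(C)=C/CC[C@H](OC)[C@@H](OC(N)=O)/C(C)=C/[C@H](C)[C@@H](OC)[C@@H](OC)C[C@@H]2C)cc1`) carries one change from compound 2: methyl in place of hydrogen on an oxygen on a saturated carbon turns hydroxy to methoxy. In this assay, going by the values given here, no step beyond the usual scatter is expected, though no measured pair tests this change. The estimate means a number no higher from compound 2 to compound 3 (the limit leaves the size open) as the expected step. Compound 3 is estimated at 20000 nM with 7000 nM and 45000 nM as its expected bounds.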

Compound 3, half-maximal inhibitory concentration: > 20000 nM
Compound 3 was reported as a limit; the forecaster's own chance of this, stated with the estimate: 60%; the middle value sits exactly at the limit.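

No step can be read from compound 2 to compound 3, because both readings are limits of the assay, not numbers: the limit of > 20000 nM in this assay, at which 2 of the 3 values shown sit.

Going by these compounds, whether turning hydroxy to methoxy changes the activity at all remains open.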